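Ketone linkage in place of a benzyl group on the core

The source may report more compounds than this note shows. Statements on the series, on what has been measured and on what is new or still open speak of the compounds shown alone.

Compound 1: `Cc1cccc(Cn2nc3cc(O[C@H]4CC[C@@H](C(=O)O)CC4)ccc3c2C)c1` gives 45 nM in an assay on isolated protein for inhibition of Long-chain-fatty-acid--CoA ligase 1 (Homo sapiens), read by mass spectrometry, with a stated time of 90 min, in the presence of a further agent that is not named here; a lower number here means a stronger inhibitor, a higher number a weaker inhibitor.
Compound 2: `Cc1ccc(Cc2nc3cc(O[C@H]4CC[C@@H](C(=O)O)CC4)ccc3n2C)cc1` gives 150 nM in this assay.

Of the compounds shown here, two that share a cyclohexane carboxylic acid ether have been measured so far. Compound 2 stands at the higher of the two numbers, with compound 1 the nearer neighbour at a lower number, a gap that lies beyond the usual scatter. The two differ in more than one place, so their values are taken only as they stand.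

Compound 3, `Cc1cccc(C(=O)c2nc3cc(O[C@H]4CC[C@@H](C(=O)O)CC4)ccc3n2C)c1`, has not yet been measured. It is reached from compound 2 by one change, ((3-methylphenyl)carbonyl in place of 4-methylbenzyl on an aromatic carbon), that is, (3-methylphenyl)carbonyl in place of 4-methylbenzyl on an aromatic carbon. For the measured compounds named here, no single-change step of this kind has been measured, so there is no precedent to lean on. The expectation for the step from compound 2 to compound 3 in this assay is therefore a small one, not clearly beyond the scatter in either direction, a 1.3-fold higher number from compound 2 to compound 3 (0.12 log units; within the scatter). Compound 3 is estimated at 200 nM, within a range from 60 nM to 700 nM.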

Compound 3, half-maximal inhibitory concentration: > 200000 nM
Compound 3 was reported as a limit; the forecaster's own chance of this, stated with the estimate: 5%; middle value at least 1000-fold (3.00 log units) away from the limit.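

For the compounds shown here, at this aromatic carbon, between two ring nitrogen atoms, (3-methylphenyl)carbonyl in place of 4-methylbenzyl gives, in this assay, an at least 1300-fold higher number from compound 2 to compound 3 (3.12 log units; beyond the scatter), the first single-change step and one well beyond the scatter. The entry for compound 3 is a limit of the assay and not a number: the limit of > 200000 nM in this assay, at which 1 of the 3 values shown sits. Both groups carry one six-membered aromatic ring of carbon only and differ in the carbonyl and in the place of the methyl, and this one change takes inhibition out of the measurable range, something compound 1 and compound 2 could not show, as they differ in more than one place.

Whether the carbonyl or the shift of the methyl accounts for the loss stays open, as the two change together in this single step. A 3-methylbenzyl group or a (4-methylphenyl)carbonyl group on this carbon would separate the two, and an amine or an ether oxygen as the link to the aromatic ring would show how far the outcome depends on the carbonyl itself.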